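A Nitro Group Gives Way to Fluoro

A few compounds are considered here, and "the series" means these few. Any claim that something is new, unique, unknown or untested is made for them only; others in the source may bear on it.

Of the compounds shown here, three have so far been tested in a functional assay on CCRF-CEM cells (Homo sapiens) for cytotoxicity, in the absence of a further agent; on this read-out higher numbers stand for weaker inhibition and lower numbers for stronger inhibition. Compound 1 `COC(=O)c1ccc(CN(CCCc2c(N)nc(N)nc2O)c2cc(F)cc(F)c2[N+](=O)[O-])cc1` gives > 100000 nM, which is a limit of the assay and not a number. Compound 3 `Nc1nc(N)c(CCCN(Cc2ccc(NC(CCC(=O)O)C(=O)O)cc2)c2cc(F)c(F)cc2[N+](=O)[O-])c(O)n1` gives > 100000 nM, which is likewise a limit of the assay. Compound 2 `CC(C)(C)OC(=O)CCC(Nc1ccc(CN(CCCc2c(N)nc(N)nc2O)c2cc(F)c([N+](=O)[O-])cc2[N+](=O)[O-])cc1)C(=O)OC(C)(C)C` gives 1500 nM, and it is the only one of the three to return an actual number.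

Compound 4 `CC(C)(C)OC(=O)CCC(Nc1ccc(CN(CCCc2c(N)nc(N)nc2O)c2cc(F)c(F)cc2[N+](=O)[O-])cc1)C(=O)OC(C)(C)C` departs from compound 2 by a single change, (fluoro in place of nitro on an aromatic carbon). This is fluoro in place of nitro on an aromatic carbon, at a place ortho to a fluoro group, meta to a nitro group and para to a large group. For the measured compounds named here, no measured pair in this small set isolates that exchange, so the size of the step has to be judged with little support. Going by the values given here, the expectation leans on one observation: compound 2, at 1500 nM, is the sole compound so far with a numerical reading. In this assay, the estimate is a 5.3-fold higher number from compound 2 to compound 4 (0.73 log units; beyond the scatter), an expected move toward weaker inhibition that goes beyond the usual scatter. For compound 4 the expected value is 8000 nM, with an estimated range from 1500 nM to 50000 nM.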

Compound 4, half-maximal inhibitory concentration: 1700 nM
Beside the measured number, compound 4's estimate is 4.7-fold (0.67 log units) above it; the range from low to high includes it.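

In this assay, putting fluoro in place of nitro on this aromatic carbon, ortho to a fluoro group, meta to a nitro group and para to a large group, gives a 1.1-fold higher number from compound 2 to compound 4 (0.05 log units; within the scatter). The earlier compounds shown here offered no measured pair for this exchange, and this pair now shows that, with everything else held the same, the two groups at this position cannot be told apart on this read-out, as the step lies within the scatter. Compound 4 also joins compound 2 as a second compound with a numerical reading, whereas the values of compound 1 and compound 3 are limits of the assay and not numbers: the limit of > 100000 nM in this assay, at which 2 of the 4 values shown sit.

Still open, from the compounds shown here alone, is how a smaller or different group on the same carbon, such as a chloro group, an amine or a plain hydrogen, would read in this assay. Also open, going by these compounds, is whether the remaining nitro group, meta to this position, could give way to a fluoro group or a nitrile with as little consequence for the reading.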